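The source may report more compounds than this note shows. Statements on the series, on what has been measured and on what is new or still open speak of the compounds shown alone.

Compound 1: `O=c1sc2ccccc2n1CCCCN1CCCCCC1`, 3.2 nM
Compound 2: `O=c1sc2ccccc2n1CCCCCN1CCCCCC1`, 7 nM

Both were tested in an assay on cell membranes for displacement of a labelled ligand from Sigma non-opioid intracellular receptor 1 (Rattus norvegicus); a lower number here means a stronger inhibitor, a higher number a weaker inhibitor. Compound 1 gives 3.2 nM, and compound 2 gives 7 nM. Of these two numbers compound 2 has the higher one, and its gap to compound 1 is beyond the usual scatter, so compound 2 is the weaker binder of the pair. The next compound, compound 3, is `CCCC(=O)c1ccc2c(c1)sc(=O)n2CCCCCN1CCCCCC1`. It differs from compound 2 in one place: propylcarbonyl in place of hydrogen on an aromatic carbon. Among the compounds with values here, no pair of measured compounds shows what such an addition does, so the expectation rests on compound 2 alone and carries a wide margin. A step in this assay of a 1.4-fold lower number from compound 2 to compound 3 (0.15 log units; within the scatter) is expected, which amounts to no clear change beyond the scatter. For compound 3 the estimated value in this assay is 5 nM, with a range from 1 nM to 25 nM.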

Compound 3, inhibition constant: 16.3 nM
Beside the measured number, compound 3's estimate is 3.3-fold (0.51 log units) below it; low and high end bracket the measured number.
By their numbers in this assay, from the lowest: compound 1; then compound 2; then compound 3.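

Within the data shown here, compound 3 gives the first reading of what a group on this aromatic carbon does. In this assay, propylcarbonyl in place of hydrogen produces a modest loss of binding (a 2.3-fold higher number from compound 2 to compound 3 (0.37 log units; beyond the scatter)), so this addition of 5 heavy atoms costs some strength but does not abolish binding, and compound 3 still gives 16.3 nM. Nothing measured here explains why the number rises.

One change at one place cannot show whether the loss follows from the length of the propyl chain, from the carbonyl, or from having any group on this carbon at all. Going by these compounds, what an acetyl group, a plain butyl chain or an amine would do on the same aromatic carbon remains open, as does whether propylcarbonyl would have the same effect on compound 1.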